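The source may hold more compounds than are shown below. What is called first, only, known or untested is meant among the compounds shown, and "the series" means these compounds.

For the measured compounds named here, compound 2 `Nc1ccccc1Cn1cncc1-c1cc2cc(Br)ccc2[nH]1` has the highest number of the two measured so far in an assay on isolated protein for inhibition of Indoleamine 2,3-dioxygenase 1 (Homo sapiens), with a stated time of 1 h (a higher number here means a weaker inhibitor, a lower number a stronger inhibitor), with compound 2 giving 50600 nM, while compound 1 `Brc1ccc2[nH]c(-c3cncn3Cc3ccccc3)cc2c1` gives 13600 nM. Going by the values given here, the one step on record, a 3.7-fold higher number from compound 1 to compound 2 (0.57 log units; beyond the scatter), shows the amino-bearing benzyl group weakening inhibition. Compound 3 `Oc1cccc(Cn2cncc2-c2cc3cc(Br)ccc3[nH]2)c1` differs from compound 2 by 3-hydroxyphenyl in place of 2-aminophenyl on a saturated chain carbon bound to an aromatic nitrogen. Among the compounds with values here, no measured step covers a hydroxyl at that position, so the swap is expected to undo at most part of the amino-linked loss, and compound 3 is estimated at 20000 nM (range 7000 nM to 60000 nM). The expected step is a 2.5-fold lower number from compound 2 to compound 3 (0.40 log units; beyond the scatter) in this assay.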

Compound 3, half-maximal inhibitory concentration: 1600 nM
Estimate against measurement, compound 3: 13-fold (1.10 log units) above; the whole stated range lies above it.
By their numbers in this assay, from the lowest: compound 3; then compound 1; then compound 2.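

Compound 3 shows that the group on a saturated chain carbon bound to an aromatic nitrogen can strengthen inhibition as well as weaken it: this assay gives an 8.5-fold lower number from compound 1 to compound 3 (0.93 log units; beyond the scatter) when a hydroxyl is added. Exchanging 2-aminophenyl for 3-hydroxyphenyl gives a 32-fold lower number from compound 2 to compound 3 (1.50 log units; beyond the scatter) with no change in the counted heavy atoms, donors or acceptors.

Open, from the compounds shown here alone, is whether the gain belongs to the hydroxyl itself or to where it sits, and whether 2-hydroxyphenyl, 3-aminophenyl, or a methoxy group would keep it. Nothing at hand bears on the reason for the gain.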